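The source may report more compounds than this note shows. Statements on the series, on what has been measured and on what is new or still open speak of the compounds shown alone.

Measured so far in a functional assay on cells (T-cell line, Homo sapiens) for inhibition; on this read-out higher numbers stand for weaker inhibition and lower numbers for stronger inhibition:
- compound 1 `COc1ccc(CCCN2CCC(COC(c3ccccc3)c3ccc(Cl)cc3)CC2)cc1`: 200 nM
- compound 2 `COc1ccc(CCCN2CCC(COC(c3ccc(Br)cc3)c3ccc(Br)cc3)CC2)cc1`: 3200 nM
- compound 3 `Clc1ccc(CCCN2CCC(COC(c3ccccc3)c3ccccc3)CC2)cc1`: 500 nM

Compound 3 stands in the middle of these three, with both gaps beyond the scatter. Compound 4 `COc1ccccc1CCCN1CCC(COC(c2ccccc2)c2ccccc2)CC1` has 2-methoxyphenyl in place of 4-chlorophenyl on a saturated chain carbon, three bonds along the chain from an amine nitrogen in a ring. Among the measured compounds shown here, no single-change step has been measured. Compound 1 also carries a methoxy-bearing phenyl on that chain and gives 200 nM, but it differs in other places too. In this assay the expected step is a 1.3-fold lower number from compound 3 to compound 4 (0.10 log units; within the scatter), none beyond the scatter. For compound 4 the estimate is 400 nM, with an expected range of 130 nM to 1300 nM.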

Compound 4, half-maximal inhibitory concentration: 2400 nM
Estimate against measurement, compound 4: 6.0-fold (0.78 log units) below; the whole stated range lies below it.
By their numbers in this assay, from the lowest: compound 1; then compound 3; then compounds 4 and 2 (each within the scatter of the next).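

In this assay, among the compounds shown here, the aryl group on a saturated chain carbon, three bonds along the chain from an amine nitrogen in a ring, proves sensitive to change: 2-methoxyphenyl in place of 4-chlorophenyl gives a 4.8-fold higher number from compound 3 to compound 4 (0.68 log units; beyond the scatter) as the first single-change step. With the rest of the structure constant, this weaker inhibition belongs to that exchange alone. No available evidence bears on the origin of this step.

From the compounds shown here alone, the exchange alters substituent and placement together, so their separate contributions remain open. Also open, going by these compounds, is how 2-chlorophenyl or 2-ethoxyphenyl would read on the same chain.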